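The source may report more compounds than this note shows. Statements on the series, on what has been measured and on what is new or still open speak of the compounds shown alone.

In a functional assay on OVCAR-8 cells (Homo sapiens) (on this read-out higher numbers stand for weaker inhibition of growth and lower numbers for stronger inhibition of growth), compound 1 `O=S(=O)(/C=C/c1ccccc1)Cc1ccc(Nc2ncnc3ccccc23)cc1` gives > 100000 nM, which is a limit of the assay and not a number. Going by the values given here, compound 2 `O=S(=O)(/C=C/c1ccc(Br)cc1)Cc1ccc(Nc2ncnc3ccccc23)cc1` gives 38000 nM, the only true number so far. Putting bromo in place of hydrogen on an aromatic carbon produced an at least 2.6-fold lower number from compound 1 to compound 2 (0.42 log units; beyond the scatter). The size of that step rests on (the limit of > 100000 nM in this assay, at which 1 of the 2 values shown sits), so it is a minimum and not an exact figure.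

Compound 3 `O=S(=O)(/C=C/c1ccc(Cl)cc1Cl)Cc1ccc(Nc2ncnc3ccccc23)cc1` has 2,4-dichlorophenyl in place of 4-bromophenyl on a double-bonded chain carbon bound to a double-bonded chain carbon. Among the compounds with values here, the bromo step is the only measured guide. Compound 3 also carries halogen on that ring, so it is expected to stay close to compound 2 at 38000 nM, perhaps with a small further fall. The expected change is a 1.5-fold lower number from compound 2 to compound 3 (0.18 log units; within the scatter), probably within the scatter. For compound 3 the estimated value is 25000 nM, with an expected range from 7000 nM to 90000 nM.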

Compound 3, concentration for 50% growth inhibition: 4000 nM
For compound 3 the middle estimate is 6.3-fold (0.80 log units) above the measured one; the whole stated range lies above it.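

Carrying halogen on this ring does not by itself settle the number, since two halogen-bearing rings at the same place on the double-bonded chain give clearly different results. In this assay, replacing 4-bromophenyl with 2,4-dichlorophenyl gives a 9.5-fold lower number from compound 2 to compound 3 (0.98 log units; beyond the scatter), so the choice of halogen pattern on this ring matters much more than the bromo step alone could show. Set against the plain phenyl ring, the change gives an at least 25-fold lower number from compound 1 to compound 3 (1.39 log units; beyond the scatter), and this size is a minimum, not an exact figure: the limit of > 100000 nM in this assay, at which 1 of the 3 values shown sits.

This single change alters the kind of halogen, the number of halogens and their placement together, so the compounds shown cannot say which of these accounts for the step. As far as these compounds go, how a ring carrying one chloro group, a methoxy group or an amine would behave at this place also stays open.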